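Methoxy for chloro on the oxindole-side ring of compound 2

This account rests on a few compounds, and the source may have more. Where it says the series, first, only, none or still open, it means among the compounds named here.

Compound 2 `COc1c(/C=C2/C(=O)Nc3ccc(Cl)cc32)c2ccccc2n1-c1ccccc1` gives 5250 nM in a functional assay on cells (Cancer cell lines, Homo sapiens) for cytotoxicity, with a stated time of 48 h (a higher number here means a weaker inhibitor of growth, a lower number a stronger inhibitor of growth), the higher of the two numbers recorded so far; compound 1 `COc1c(/C=C2/C(=O)Nc3ccccc32)c2ccccc2n1-c1ccccc1` gives 2190 nM. Going by the values given here, the only step measured, a 2.4-fold higher number from compound 1 to compound 2 (0.38 log units; beyond the scatter), concerns the same aromatic carbon that now changes again: in compound 3 `COc1ccc2c(c1)/C(=C\c1c(OC)n(-c3ccccc3)c3ccccc13)C(=O)N2` the change is methoxy in place of chloro on an aromatic carbon. Among the compounds with values here, no measured step tests a methoxy at this place, so the direction is open; a return toward the number of compound 1 is as plausible as no movement beyond the scatter. Compound 3 is therefore expected near 3500 nM, within 1200 nM to 10000 nM. This estimate amounts to a 1.5-fold lower number from compound 2 to compound 3 (0.18 log units; within the scatter).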

Compound 3, concentration for 50% growth inhibition: 980 nM
Compound 3: the middle estimate sits 3.6-fold (0.55 log units) above what was measured, and the stated range ends above it.
By their numbers in this assay, from the lowest: compound 3; then compound 1; then compound 2.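

In this assay, methoxy in place of hydrogen gives a 2.2-fold lower number from compound 1 to compound 3 (0.35 log units; beyond the scatter) at this aromatic carbon, so a substituent here can lower the number, which the chloro of compound 2 did not show. Methoxy in place of chloro gives a 5.4-fold lower number from compound 2 to compound 3 (0.73 log units; beyond the scatter) and reverses the direction of the chloro step, so the outcome at this carbon depends on the group placed there. Nothing available accounts for this difference between methoxy and chloro. Going by these compounds, whether a hydroxyl, an amine or a longer alkoxy chain at this carbon would follow methoxy remains open. So does the effect of methoxy on the other carbons of this ring.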